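The source may report more compounds than this note shows. Statements on the series, on what has been measured and on what is new or still open speak of the compounds shown alone.

Within the data shown here, in an assay on isolated protein for inhibition of kallikrein-7 (Mus musculus), read by fluorescence, with stated times of 10 min and 30 min (a lower number here means a stronger inhibitor, a higher number a weaker inhibitor), compound 2 `CC1=NC(c2cn(S(=O)(=O)c3ccccc3C#N)c3ccc(C)cc23)CN1` gives 11000 nM, which is the only actual number reported for any compound here. Compound 1 `CC1=NC(c2cn(S(=O)(=O)c3ccc(F)cc3)c3ccc(C)cc23)CN1` gives > 30000 nM in this assay, and this is a limit rather than a measured number, namely (the limit of > 30000 nM in this assay, at which 1 of the 2 values shown sits). Among the measured compounds shown here, the single measured step, an at least 2.7-fold lower number from compound 1 to compound 2 (0.43 log units; beyond the scatter), is the only indication of how the group on the sulfonyl sulfur matters. Compound 3 `CC1=NC(c2cn(S(=O)(=O)c3c(Cl)cccc3Cl)c3ccc(C)cc23)CN1` changes the same place once more: 2,6-dichlorophenyl in place of 2-cyanophenyl on a sulfonyl sulfur. For the measured compounds named here, no measured step involves a 2,6-dichlorophenyl, so the expectation can draw only on the one step seen, which was at least modest. The step is expected to be a 1.4-fold lower number from compound 2 to compound 3 (0.14 log units; within the scatter), possibly no larger than the scatter. The estimate for compound 3 in this assay is 8000 nM, with a range from 2500 nM to 30000 nM.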

Compound 3, half-maximal inhibitory concentration: 10000 nM
Compound 3: middle estimate off by 1.3-fold (0.10 log units), on the low side, within the range that was stated.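

In this assay, two different groups on the sulfonyl sulfur, 2-cyanophenyl and 2,6-dichlorophenyl, give values that cannot be told apart: a 1.1-fold lower number from compound 2 to compound 3 (0.04 log units; within the scatter). The nitrile of compound 2 is therefore not required to reach this level, as compound 3 carries none, and replacing 4-fluorophenyl with a second group also gives an at least 3.0-fold lower number from compound 1 to compound 3 (0.47 log units; beyond the scatter). Compound 1 has a limit, not a measured number, so the true size of this step stays unknown: the limit of > 30000 nM in this assay, at which 1 of the 3 values shown sits.

As far as these compounds go, it remains open whether a single chlorine on the phenyl ring would give a similar value to the two chlorines of compound 3. From the compounds shown here alone, it is also open whether a group other than a substituted phenyl ring on the sulfonyl sulfur, such as a short alkyl chain, or a phenyl ring bearing an amine or a carboxylic acid, would shift the number further.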